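Swapping the butyl triazole for an acetamide

The compounds below may be only part of what the source reports. "The series", "measured", "known", "first", "only" and "open" are said of these compounds alone.

Compound 1 `CCCCCCCCCCCCC/C=C/[C@@H](O)[C@H](CO)n1cc(CCC)nn1`: 13000 nM
Compound 2 `CCCCCCCCCCCCC/C=C/[C@@H](O)[C@H](CO)n1cc(CCCCCC)nn1`: 8200 nM
Compound 3 `CCCCCCCCCCCCC/C=C/[C@@H](O)[C@H](CO)n1cc(CCCC)nn1`: 12300 nM

These three compounds share one core and differ only in the chain on the triazole ring; all were tested in a functional assay on K562 cells (Homo sapiens) for cytotoxicity, read by MTT assay; a higher number here means that more compound is needed for the effect, a lower number that less compound is needed. Compound 3 stands second highest of the three numbers, and the steps of a 1.1-fold lower number from compound 1 to compound 3 (0.02 log units; within the scatter) and a 1.5-fold higher number from compound 2 to compound 3 (0.18 log units; within the scatter) both lie within the scatter, so the three are not separated. Compound 4 `CCCCCCCCCCCCC/C=C/[C@@H](O)[C@H](CO)NC(C)=O` carries a different change: acetamido in place of 4-butyl-1H-1,2,3-triazol-1-yl on a saturated chain carbon bound to two saturated chain carbons. For the measured compounds named here, no measured step replaces the ring itself; the steps of a 1.6-fold lower number from compound 1 to compound 2 (0.20 log units; within the scatter) and a 1.1-fold lower number from compound 1 to compound 3 (0.02 log units; within the scatter) only lengthen or shorten its chain and stay within the scatter, so they give no direction for this swap. Compound 4 is therefore expected near compound 3, estimated at 15000 nM with a range from 5000 nM to 50000 nM. The expected step is a 1.2-fold higher number from compound 3 to compound 4 (0.09 log units; within the scatter).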

Compound 4, half-maximal effective concentration: 35100 nM
Estimate against measurement, compound 4: 2.3-fold (0.37 log units) below; low and high end bracket the measured number.
By their numbers in this assay, from the lowest: compounds 2, 3 and 1 (each within the scatter of the next); then compound 4.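

Replacing the triazole itself shifts the number in this assay beyond the scatter (a 2.9-fold higher number from compound 3 to compound 4 (0.46 log units; beyond the scatter)) and (a 2.7-fold higher number from compound 1 to compound 4 (0.43 log units; beyond the scatter)), which no change of chain length on the ring did among compounds 1, 2 and 3. At this saturated chain carbon, then, swapping the whole group counts for more than altering its chain, though the step is modest. No measurement here explains the shift.

Going by these compounds, it stays open whether the ring or simply the larger group matters, and how a free amine or a longer acyl chain would read here.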